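Swapping a Cyclopentenyl Ring for a Butyl Chain

This account rests on a few compounds, and the source may have more. Where it says the series, first, only, none or still open, it means among the compounds named here.

Of the compounds shown here, three built on a shared core have been measured in a functional assay on HEK293 cells for agonist activity at Free fatty acid receptor 1 (Homo sapiens), read by fluorescence and calcium flux, with a stated time of 1 h; a higher number here means that more compound is needed for the effect, a lower number that less compound is needed. Compound 1 `COc1ccc(F)c(-c2cnc(COc3cccc([C@@H](CC(=O)O)C4CC4)c3)cc2C2=CCCC2(C)C)c1` gives 11 nM. Compound 2 `COc1ccc(F)c(-c2ncc(COc3cccc([C@@H](CC(=O)O)C4CC4)c3)cc2C2=CCCC2(C)C)c1` gives 21.3 nM. Compound 3 `COc1ccc(F)c(-c2ncc(COc3cccc([C@@H](CC(=O)O)C4CC4)c3)nc2C2=CCCC2(C)C)c1` gives 37 nM, the highest of the three numbers. The gap between compound 3 and compound 2 lies within the scatter of repeated measurements, so the two cannot be told apart on these numbers. The gap to compound 1 is wider and lies beyond that scatter, so compound 3 needs more material than compound 1 to reach the same effect.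

Compound 4 `CCCCc1nc(COc2cccc([C@@H](CC(=O)O)C3CC3)c2)cnc1-c1cc(OC)ccc1F` has not yet been measured. It differs from compound 3 in one place: butyl in place of 5,5-dimethylcyclopent-1-en-1-yl on an aromatic carbon. Within the data shown here, no pair among the measured compounds shows what this kind of exchange does, so there is no direct step to lean on. The ring is removed and a shorter open chain takes its place on the same aromatic carbon. A modest move toward a higher number in this assay is expected, though it may well stay within the scatter. In this assay compound 4 is expected to give 80 nM, within a range from 25 nM to 300 nM. This estimate means a step from compound 3 to compound 4 of a 2.2-fold higher number from compound 3 to compound 4 (0.33 log units; beyond the scatter).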

Compound 4, half-maximal effective concentration: 2.5 nM
Estimate against measurement, compound 4: 32-fold (1.51 log units) above, and the stated range ends above it.
By their numbers in this assay, from the lowest: compound 4; then compounds 1, 2 and 3 (each within the scatter of the next, the first and the last beyond it).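

Exchanging 5,5-dimethylcyclopent-1-en-1-yl for butyl on this aromatic carbon, next to the ring nitrogen and ortho to the 2-fluoro-5-methoxyphenyl group, gives in this assay a 15-fold lower number from compound 3 to compound 4 (1.17 log units; beyond the scatter), a large step. For this pair, then, the position does not depend on the ring or its double bond: the smaller open butyl chain needs far less compound for the same effect. Nothing measured here bears on why the step is so large.

The compounds shown leave open whether this result belongs to butyl itself or to open chains more broadly, and a propyl chain, a pentyl chain or a cyclopentyl group at the same carbon would help separate those readings. They also leave open whether butyl would bring a similar change on the core of compound 1 or compound 2, both of which carry 5,5-dimethylcyclopent-1-en-1-yl.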